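The source may report more compounds than this note shows. Statements on the series, on what has been measured and on what is new or still open speak of the compounds shown alone.

Compound 1 `CCC(=O)Nc1c(C(O)(C(F)(F)F)C(F)(F)F)ccc2ccccc12` gives 15 nM in an assay on LtK cells with ATP-sensitive inward rectifier potassium channel 11 (Homo sapiens) as the target; a higher number here means that more compound is needed for the effect, a lower number that less compound is needed.
Compound 2 `O=C(Nc1c(C(O)(C(F)(F)F)C(F)(F)F)ccc2ccccc12)c1ccccc1Cl` gives 2040 nM in this assay.
Compound 3 `COc1cccc(C(=O)Nc2c(C(O)(C(F)(F)F)C(F)(F)F)ccc3ccccc23)c1` gives 185 nM in this assay.

All three compounds share the same core and differ only in the group attached to the carbonyl carbon of the amide. For the measured compounds named here, on the numbers so far, compound 3 holds the second highest value of the three: its nearest neighbour is reached by an 11-fold lower number from compound 2 to compound 3 (1.04 log units; beyond the scatter), its most distant one by a 12-fold higher number from compound 1 to compound 3 (1.09 log units; beyond the scatter).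

Compound 4 `O=C(Nc1c(C(O)(C(F)(F)F)C(F)(F)F)ccc2ccccc12)c1ccc(Cl)c(Cl)c1` is the next compound, and it differs from compound 3 in one place: 3,4-dichlorophenyl in place of 3-methoxyphenyl on a carbonyl carbon.

Three measured steps speak to this change. a 140-fold higher number from compound 1 to compound 2 (2.13 log units; beyond the scatter) and a 12-fold higher number from compound 1 to compound 3 (1.09 log units; beyond the scatter) show that each six-membered aromatic ring placed on the carbonyl carbon gave a clearly higher number than ethyl did. an 11-fold lower number from compound 2 to compound 3 (1.04 log units; beyond the scatter) shows that, of the two aromatic rings measured, the 2-chlorophenyl gave the higher number and the 3-methoxyphenyl the lower. Going by the values given here, no measured step covers a 3,4-dichlorophenyl, so the expectation is rough. Compound 4 is therefore expected to give a somewhat higher number than compound 3, a step of about a 2.4-fold higher number from compound 3 to compound 4 (0.39 log units; beyond the scatter) in this assay. The estimate for compound 4 is 450 nM, with a range from 100 nM to 2500 nM.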

Compound 4, half-maximal effective concentration: 194 nM
Compound 4: middle estimate off by 2.3-fold (0.37 log units), on the high side; the measured number falls inside the stated range.
By their numbers in this assay, from the lowest: compound 1; then compounds 3 and 4 (each within the scatter of the next); then compound 2.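

Putting 3,4-dichlorophenyl in place of 3-methoxyphenyl on the carbonyl carbon gives a 1.0-fold higher number from compound 3 to compound 4 (0.02 log units; within the scatter), so these two groups cannot be told apart in this assay, even though they differ in their atoms and only 3-methoxyphenyl counts a hydrogen-bond acceptor. The presence of chlorine therefore does not by itself go with the highest number among these compounds: 3,4-dichlorophenyl in place of 2-chlorophenyl gives an 11-fold lower number from compound 2 to compound 4 (1.02 log units; beyond the scatter), while 3,4-dichlorophenyl in place of ethyl gives a 13-fold higher number from compound 1 to compound 4 (1.11 log units; beyond the scatter), making it the third aromatic ring on this carbon to give a clearly higher number than ethyl. Nothing available here explains any of these differences.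

Going by these compounds, it remains open whether a longer chain such as butyl, or an amine on the carbonyl carbon, would stay close to the ethyl compound or move towards the aromatic ones. With only three aromatic rings shown, it is also unclear whether the gap separating 2-chlorophenyl from the other two follows where chlorine sits on the ring or some other difference between these groups.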